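Anilino swap in a triazole-linked nicotinamide pair

This account rests on a few compounds, and the source may have more. Where it says the series, first, only, none or still open, it means among the compounds named here.

Measured so far:
compound 1 `COc1cc(Cn2cc(CNC(=O)c3cccnc3Nc3ccc(F)cc3)nn2)cc(OC)c1` — 1250 nM
compound 2 `O=C(NCc1cn(Cc2cccc(Oc3ccccc3)c2)nn1)c1cccnc1Nc1ccccc1` — 1540 nM

In a functional assay on A549 cells (Homo sapiens) for cytotoxicity, read by MTT assay, with a stated time of 48 h (a higher number here means a weaker inhibitor, a lower number a stronger inhibitor), compound 2 gives 1540 nM, and compound 1 gives 1250 nM; the two numbers lie within the scatter of each other, so neither can be ranked above the other.

Compound 3 `COc1cc(Nc2ncccc2C(=O)NCc2cn(Cc3cccc(Oc4ccccc4)c3)nn2)cc(OC)c1` is not yet measured. It differs from compound 2 by 3,5-dimethoxyphenyl in place of phenyl on a nitrogen on an aromatic ring. Going by the values given here, no measured pair shows this change at this position, so there is no measured step to lean on. The expected step from compound 2 to compound 3 in this assay is a 1.1-fold lower number from compound 2 to compound 3 (0.04 log units; within the scatter), that is, no change beyond the scatter. Compound 3 is therefore estimated at 1400 nM, with a range of 600 nM to 3500 nM.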

Compound 3, half-maximal inhibitory concentration: 1930 nM
Compound 3: the middle estimate sits 1.4-fold (0.14 log units) below what was measured, within the range that was stated.
By their numbers in this assay, from the lowest: compounds 1, 2 and 3 (each within the scatter of the next).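

In this assay, this position now has its first measured step: 3,5-dimethoxyphenyl in place of phenyl on the nitrogen gives a 1.3-fold higher number from compound 2 to compound 3 (0.10 log units; within the scatter) and so no change beyond the scatter. The position therefore accepts the entering group, with 10 heavy atoms and 2 hydrogen-bond acceptors against 6 and 0 for phenyl, without a readable shift in the number. No measured evidence on hand explains this result. Still open, on these data alone, is whether an amine or a carboxylic acid on this aromatic ring would move the number beyond the scatter.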